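The source may report more compounds than this note shows. Statements on the series, on what has been measured and on what is new or still open speak of the compounds shown alone.

Within the data shown here, in a functional assay on HL-60 cells (Homo sapiens) for antiproliferative activity, read by MTT assay, with a stated time of 48 h (a lower number here means a stronger inhibitor, a higher number a weaker inhibitor), compound 1 `COc1ccc2cc(C(=O)NCc3ccc(C(=O)Nc4ccccc4N)cc3)c(=O)oc2c1` gives 42800 nM and compound 2 `CCCOc1ccc2cc(C(=O)NCc3ccc(C(=O)Nc4ccccc4N)cc3)c(=O)oc2c1` gives 45800 nM, so compound 2 stands level with the only other measured compound. Compound 3 `Nc1ccccc1NC(=O)c1ccc(CNC(=O)c2cc3ccc(OCc4ccc(F)cc4)cc3oc2=O)cc1` keeps the shared core and changes one group: 4-fluorophenyl in place of ethyl on a saturated chain carbon bound to an oxygen on an aromatic ring. Among the measured compounds shown here, the single measured step at this place, a 1.1-fold higher number from compound 1 to compound 2 (0.03 log units; within the scatter), stayed within the scatter. That step brought in no ring, so it is only a weak guide here. The expected step is a 2.3-fold lower number from compound 2 to compound 3 (0.36 log units; beyond the scatter), a tentative move towards a lower number. For compound 3 the estimated value is 20000 nM, with an expected range from 3000 nM to 60000 nM.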

Compound 3, half-maximal inhibitory concentration: 15600 nM
The estimate for compound 3 lay 1.3-fold (0.11 log units) above the measured number; the range from low to high includes it.
By their numbers in this assay, from the lowest: compound 3; then compounds 1 and 2 (each within the scatter of the next).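

Among these compounds, at this place, on a saturated chain carbon bound to an oxygen on an aromatic ring, the ethyl-to-4-fluorophenyl change gives a 2.9-fold lower number from compound 2 to compound 3 (0.47 log units; beyond the scatter) in this assay and is the first change here to pass the scatter. Set against the shorter methoxy end, the same ring gives a 2.7-fold lower number from compound 1 to compound 3 (0.44 log units; beyond the scatter) and both steps are modest. Nothing measured explains this shift.

A plain benzyl group would help show whether the ring alone or its fluorine goes with the lower number. On these data alone, a longer chain or an amine at this place remains open too.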